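The source may hold more compounds than are shown below. What is called first, only, known or untested is meant among the compounds shown, and "the series" means these compounds.

In a functional assay on SW-620 cells (Homo sapiens) for antiproliferative activity, read by MTT assay, with a stated time of 24 h (a lower number here means a stronger inhibitor, a higher number a weaker inhibitor), the measured compounds and their values are these:

Compound 1 `COc1ccc(C(=O)/C=C/c2ccc3ccccc3n2)c2c1C=CC(C)(C)O2` gives 2250 nM.
Compound 2 `COc1ccc(C(=O)/C=C/c2ccc([N+](=O)[O-])cc2)c2c1C=CC(C)(C)O2` gives 3520 nM.
Compound 3 `COc1ccc(C(=O)/C=C/c2cccc3ccccc23)c2c1C=CC(C)(C)O2` gives only a limit of the assay, > 10000 nM.

Among the two numbers, compound 2 carries the higher one, but its nearest neighbour, compound 1, lies within the usual scatter of it, so the two cannot be told apart. For compound 3 the result is a limit and not a number (the limit of > 10000 nM in this assay, at which 1 of the 3 values shown sits). The shared core of all three is the same, and only the group at the end of the enone differs.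

Compound 4 `COc1ccc(C(=O)/C=C/c2ccc(O)cc2)c2c1C=CC(C)(C)O2` has not yet been measured in this assay. It differs from compound 2 in one place: hydroxy in place of nitro on an aromatic carbon. Among the measured compounds shown here, no measured pair in this set shows what that change does, so the expectation for compound 4 rests on the numbers of compound 1 and compound 2 alone. The step from compound 2 to compound 4 is expected to be small, of no clear direction and not beyond the scatter, a 1.1-fold lower number from compound 2 to compound 4 (0.04 log units; within the scatter). Compound 4 is therefore estimated at 3200 nM, within a range from 1000 nM to 10000 nM.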

Compound 4, half-maximal inhibitory concentration: > 10000 nM
Compound 4 was reported as a limit; the forecaster's own chance of this, stated with the estimate: 15%; middle value at least 3.1-fold (0.49 log units) away from the limit.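

In this assay, among the compounds shown here, hydroxy in place of nitro gives the first step in this set that can be read between two compounds differing in one place: an at least 2.8-fold higher number from compound 2 to compound 4 (0.45 log units; beyond the scatter). Compound 4 gives > 10000 nM, which is a limit of the assay and not a number. The aromatic carbon para to a large group is thus not indifferent to what it carries, and with hydroxy there a second compound of the set stands at the limit: the limit of > 10000 nM in this assay, at which 2 of the 4 values shown sit.

The compounds shown leave open how an amine, a methoxy group or a fluorine atom on this same carbon would read, and so whether the step reflects the nitro group leaving or the hydroxy group entering. A single pair also cannot say whether the same change would act alike at any other carbon of this aromatic ring.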